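Carboxymethyl to acetoxy on the shared chain

The compounds below may be only part of what the source reports. "The series", "measured", "known", "first", "only" and "open" are said of these compounds alone.

Three compounds share one core and differ at a single saturated chain carbon. In an assay for inhibition of Polyunsaturated fatty acid 5-lipoxygenase (Rattus norvegicus) (on this read-out higher numbers stand for weaker inhibition and lower numbers for stronger inhibition), compound 1 `CCCCC/C=C\C/C=C\C/C=C\C=C\C(CCCS)CCCC(=O)O` gives 36000 nM, compound 2 `CCCCC/C=C\C/C=C\C/C=C\C=C\C(CCCC(=O)O)CC(=O)NO` gives 190 nM, and compound 3 `CCCCC/C=C\C/C=C\C/C=C\C=C\C(CCCC(=O)O)CC(=O)O` gives 96000 nM. Compound 3 stands highest of the three and is the weakest inhibitor of the set, since a 2.7-fold higher number from compound 1 to compound 3 (0.43 log units; beyond the scatter) and a 510-fold higher number from compound 2 to compound 3 (2.70 log units; beyond the scatter) are both beyond the scatter.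

Compound 4 `CCCCC/C=C\C/C=C\C/C=C\C=C\C(CCCC(=O)O)OC(C)=O` keeps the atoms of compound 3 but joins them differently: acetoxy in place of carboxymethyl on a saturated chain carbon bound to a double-bonded chain carbon and a saturated chain carbon. Among the measured compounds shown here, no measured step swaps these two groups. The nearest guide is the exchange of the 2-sulfanylethyl group for carboxy, a 2.7-fold higher number from compound 1 to compound 3 (0.43 log units; beyond the scatter), a modest step, whereas the large step of a 510-fold higher number from compound 2 to compound 3 (2.70 log units; beyond the scatter) concerns the hydroxyamino group, which compound 4 lacks. For compound 4 a modest step towards a lower number is therefore expected, a 2.4-fold lower number from compound 3 to compound 4 (0.38 log units; beyond the scatter), with no strong gain foreseen. Compound 4 is estimated at 40000 nM in this assay, within a range of 8000 nM to 200000 nM.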

Compound 4, half-maximal inhibitory concentration: 68000 nM
For compound 4 the middle estimate is 1.7-fold (0.23 log units) below the measured one; the measured number falls inside the stated range.
By their numbers in this assay, from the lowest: compound 2; then compounds 1, 4 and 3 (each within the scatter of the next, the first and the last beyond it).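

In this assay, acetoxy in place of carboxymethyl on a saturated chain carbon bound to a double-bonded chain carbon and a saturated chain carbon gives a 1.4-fold lower number from compound 3 to compound 4 (0.15 log units; within the scatter), so rejoining the same atoms, with the hydrogen-bond donor count going from 1 to 0, does not separate these two compounds. Compound 4 also cannot be told apart from compound 1, with a 1.9-fold higher number from compound 1 to compound 4 (0.28 log units; within the scatter), although compound 1 and compound 3 lie just beyond the scatter of each other. Compound 2 stays apart from compound 4, with a 360-fold higher number from compound 2 to compound 4 (2.55 log units; beyond the scatter), so among these compounds a large step at this carbon appears only with (hydroxycarbamoyl)methyl.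

As far as these compounds go, whether an amine or a longer chain ending in hydroxycarbamoyl at this carbon would hold the number of compound 2 stays open. No measurement shown bears on the reason for these readings.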